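A few compounds are considered here, and "the series" means these few. Any claim that something is new, unique, unknown or untested is made for them only; others in the source may bear on it.

- Compound 1 `Cc1ccccc1-c1nc(CN2CCC(C(=O)NCCCN3CC(C)(C)CC(C)(C)C3)CC2)c(C)o1`: > 1390 10^-6 cm/s, a limit of the assay, not a number
- Compound 2 `Cc1ccccc1-c1nc(CN2CCC(C(=O)NCCCN3CCC(C)CC3)CC2)c(C)o1`: 425 10^-6 cm/s
- Compound 3 `Cc1ccccc1-c1nc(CN2CCC(C(=O)NCCCN3CCCCC3)CC2)c(C)o1`: 34.5 10^-6 cm/s

All three values come from a physicochemical assay for permeability, using PAMPA; on this read-out higher numbers stand for higher permeability and lower numbers for lower permeability. Compound 3 stands lowest, and both steps that lead to it are large and beyond the scatter: a 12-fold lower number from compound 2 to compound 3 (1.09 log units; beyond the scatter) and an at least 40-fold lower number from compound 1 to compound 3 (1.60 log units; beyond the scatter). Compound 4 `Cc1ccccc1-c1nc(CN2CCC(C(=O)NCCCN3CC4CCCC(C4)C3)CC2)c(C)o1` has not yet been measured. It differs from compound 3 in one place, on a saturated chain carbon, three bonds along the chain from an amide-type nitrogen: a group of 9 heavy atoms (8 carbon, 1 nitrogen; one six-membered non-aromatic ring of carbon only, one six-membered non-aromatic ring with 1 hetero atom) in place of a group of 6 heavy atoms (5 carbon, 1 nitrogen; one six-membered non-aromatic ring with 1 hetero atom), on a saturated chain carbon, three bonds along the chain from an amide-type nitrogen.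

Both steps bear on this change. Read in reverse, each one adds carbon to the same ring group of compound 3. Among these three compounds, the group with more carbon goes with the higher number, and none goes against this. Among the measured compounds shown here, the entering group is larger than that of compound 2, but it brings a second ring that no measured compound has, so the expectation stays loose. A large rise in this assay is expected, estimated as a 14-fold higher number from compound 3 to compound 4 (1.16 log units; beyond the scatter). For compound 4 the estimated value is 500 10^-6 cm/s, with an expected range from 130 10^-6 cm/s to 1400 10^-6 cm/s.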

Compound 4, apparent permeability: 331 10^-6 cm/s
Compound 4: the middle estimate sits 1.5-fold (0.18 log units) above what was measured; the measured number falls inside the stated range.
By their numbers in this assay, from the lowest: compound 3; then compounds 4 and 2 (each within the scatter of the next). At a limit, above all of these: compound 1.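

In this assay, the rise that came with added carbon at this place, on a saturated chain carbon, three bonds along the chain from an amide-type nitrogen, also holds for a group with a second ring: a 9.6-fold higher number from compound 3 to compound 4 (0.98 log units; beyond the scatter). Heavy atom count alone does not order these compounds, however, since compound 4 goes against the earlier trend by not standing clearly apart from the smaller group of compound 2: a 1.3-fold lower number from compound 2 to compound 4 (0.11 log units; within the scatter). A larger group with a single ring still stands apart, an at least 4.1-fold lower number from compound 1 to compound 4 (0.62 log units; beyond the scatter), though this step starts from a limit and not a number: the limit of > 1390 10^-6 cm/s in this assay, at which 1 of the 4 values shown sits.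

The compounds shown leave open whether the total carbon or its arrangement on the ring matters more. They also leave open how a morpholin-4-yl group, which has oxygen in the ring, would read at this place.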